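A few compounds are considered here, and "the series" means these few. Any claim that something is new, unique, unknown or untested is made for them only; others in the source may bear on it.

Measured so far:
compound 1, `CCn1c(-c2cnc(C)nc2)nc2c(O[C@H]3CCN(C(=O)C4CC4)C3)ncnc21`, 0.7 L/kg
compound 2, `CCn1c(-c2ccc(C(F)(F)F)nc2)nc2c(O[C@H]3CCN(C(=O)N4CC(OC)C4)C3)ncnc21`, 1.7 L/kg

In an ADME assay (Canis lupus familiaris, strain Beagle) for pharmacokinetics (on this read-out higher numbers stand for wider distribution into tissues and lower numbers for narrower distribution), compound 1 gives the lower of the two numbers; compound 2 gives a higher one, and that gap lies beyond the usual scatter. Within the data shown here, no step between compounds that differ in a single place has been measured here. Compound 3, `CCn1c(-c2cnc(C)nc2)nc2c(O[C@H]3CCN(C(=O)C4CCC4)C3)ncnc21`, differs from compound 1 in one place: cyclobutyl in place of cyclopropyl on a carbonyl carbon. Among the measured compounds shown here, with no measured step of this kind to lean on, the change from compound 1 to compound 3 is expected to be small, a 1.1-fold higher number from compound 1 to compound 3 (0.06 log units; within the scatter), not beyond the scatter. Compound 3 is therefore estimated at 0.8 L/kg, expected to fall between 0.5 L/kg and 1.4 L/kg.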

Compound 3, volume of distribution: 1.4 L/kg
Compound 3: middle estimate off by 1.8-fold (0.24 log units), on the low side; the range from low to high includes it.
By their numbers in this assay, from the lowest: compounds 1, 3 and 2 (each within the scatter of the next, the first and the last beyond it).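

In this assay, among these compounds, cyclobutyl in place of cyclopropyl on a carbonyl carbon gives a 2.0-fold higher number from compound 1 to compound 3 (0.30 log units; within the scatter) as the first measured step that changes one place only. Among the compounds shown here, at this position, then, the larger carbon ring leaves the distribution read-out inside the usual scatter, though only this one swap has been read here.

Still open, as far as these compounds go, is whether cyclopentyl, cyclohexyl or an open chain such as tert-butyl on the same carbonyl carbon would move the number beyond the scatter. Nothing measured here explains the size of this step.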